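From Dichlorobenzyl to Fluorobenzyl in a Thiourea Series

The source may report more compounds than this note shows. Statements on the series, on what has been measured and on what is new or still open speak of the compounds shown alone.

Compound 1 `Cc1ccc(NC(=S)NC(=O)c2ccc(OCc3ccc(C(F)(F)F)cc3)cc2)cc1-c1nc2ccccc2[nH]1` gives 10200 nM in a functional assay on MNK45 cells (Homo sapiens) for inhibition, read by MTT assay, with a stated time of 48 h (a lower number here means a stronger inhibitor, a higher number a weaker inhibitor), and compound 2 `Cc1ccc(NC(=S)NC(=O)c2ccc(OCc3ccc(Cl)c(Cl)c3)cc2)cc1-c1nc2ccccc2[nH]1` gives 8410 nM in the same assay. The step of a 1.2-fold lower number from compound 1 to compound 2 (0.08 log units; within the scatter). Compound 2 holds the lower of the two numbers, with compound 1 nearest and within the scatter. Compound 3 `Cc1ccc(NC(=S)NC(=O)c2ccc(OCc3ccc(F)cc3)cc2)cc1-c1nc2ccccc2[nH]1` differs from compound 2 by 4-fluorophenyl in place of 3,4-dichlorophenyl on a saturated chain carbon bound to an oxygen on an aromatic ring. For the measured compounds named here, only the step from compound 1 to compound 2, which stayed within the scatter, bears on this change, so no step beyond the scatter is expected in this assay. Compound 3 is therefore estimated at 10500 nM, within 4000 nM to 28000 nM, an expected step of a 1.2-fold higher number from compound 2 to compound 3 (0.10 log units; within the scatter).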

Compound 3, half-maximal inhibitory concentration: 4220 nM
Estimate against measurement, compound 3: 2.5-fold (0.40 log units) above, within the range that was stated.
By their numbers in this assay, from the lowest: compounds 3, 2 and 1 (each within the scatter of the next, the first and the last beyond it).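

In this assay, the change to 4-fluorophenyl on a saturated chain carbon bound to an oxygen on an aromatic ring is a 2.0-fold lower number from compound 2 to compound 3 (0.30 log units; within the scatter). Fluoro in place of trifluoromethyl on an aromatic carbon is a 2.4-fold lower number from compound 1 to compound 3 (0.38 log units; beyond the scatter), so, unlike the earlier step, this pair shows that a change at this position can move the number, though only modestly. No measurement shown explains this step.

On these data alone, whether an amine, a carboxylic acid or a longer chain at this position would carry the number further remains open.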